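Ethylamino to methylamino across two related cores

The source may hold more compounds than are shown below. What is called first, only, known or untested is meant among the compounds shown, and "the series" means these compounds.

Compound 1 `CCNc1nc(NCc2ccc(NC(=O)c3ccc(F)cc3)cc2)c2ccccc2n1` and compound 3 `CNc1nc(NCc2ccc(NC(=O)c3ccc(F)cc3)cc2)c2ccccc2n1` share one core; compound 2 `CCNc1ncc(C)c(NCc2ccc(NC(=O)c3ccc(F)cc3)cc2)n1` and the not yet measured compound 4 `CNc1ncc(C)c(NCc2ccc(NC(=O)c3ccc(F)cc3)cc2)n1` share another. How the core of compound 2 differs from the core of compound 1 is not broken down here. In a functional assay on SW480 cells (Homo sapiens) for inhibition, read by luminescence and resazurin assay, with a stated time of 3 days (on this read-out lower numbers stand for stronger inhibition and higher numbers for weaker inhibition), compound 1 gives 2300 nM. In this assay compound 3 gives 2000 nM. The step of a 1.2-fold lower number from compound 1 to compound 3 (0.06 log units; within the scatter) goes with hydrogen in place of methyl on a saturated chain carbon bound to a nitrogen on an aromatic ring. For compound 2 only a limit is recorded in this assay, namely > 20000 nM; this is the limit of > 20000 nM in this assay, at which 1 of the 3 values shown sits. The change from compound 2 to compound 4 is the same one, (hydrogen in place of methyl on a saturated chain carbon bound to a nitrogen on an aromatic ring). On the core of compound 1 this change left the number within the scatter, so a similar outcome is expected on the core of compound 2, where the starting point is already a limit. Compound 4 is therefore expected near 25000 nM, with a range from 10000 nM to 60000 nM, and most likely reported again only as a limit. The expected step that the limit leaves unreadable from compound 2 to compound 4 is accordingly small.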

Compound 4, half-maximal inhibitory concentration: > 20000 nM
Compound 4 ended at the assay's limit (the forecaster's own chance of this, stated with the estimate: 75%); the middle value lies beyond the limit too.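

Compound 2 and compound 4 both end at a limit in this assay, so the step between them cannot be read: the limit of > 20000 nM in this assay, at which 2 of the 4 values shown sit.

The compounds shown leave open whether ethylamino to methylamino changes the number at all on the core of compound 2, as neither compound has a value that can be read as a number.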